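The source may hold more compounds than are shown below. What is called first, only, known or untested is meant among the compounds shown, and "the series" means these compounds.

The compounds measured so far, with their values in a toxicity assay on CCRF-CEM cells (Homo sapiens) for cytotoxicity; a higher number here means that more compound is tolerated, a lower number that less compound is tolerated:

Compound 1, `Cc1cccc2c1nc(-c1c(F)cccc1F)n2Cc1c(F)cccc1F`: > 100 uM
Compound 2, `Fc1cccc(F)c1Cn1c(-c2c(F)cccc2F)nc2c(Cl)cccc21`: 30.4 uM
Compound 3, `CC(=O)Nc1cccc2c1nc(-c1c(F)cccc1F)n2Cc1c(F)cccc1F`: 39.3 uM

The value of compound 1 in this assay is a limit of the assay, not a number (the limit of > 100 uM in this assay, at which 1 of the 3 values shown sits). Among the two numbers, compound 3 sits highest, with compound 2 nearest at a 1.3-fold higher number from compound 2 to compound 3 (0.11 log units; within the scatter). From compound 1 the two substituted compounds drop: an at least 3.2-fold lower number from compound 1 to compound 2 (0.51 log units; beyond the scatter) and an at least 2.5-fold lower number from compound 1 to compound 3 (0.40 log units; beyond the scatter).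

The next compound, compound 4, `O=Cc1cccc2c1nc(-c1c(F)cccc1F)n2Cc1c(F)cccc1F`, has not yet been measured in this assay. It differs from compound 3 in one place: formyl in place of acetamido on an aromatic carbon.

Within the data shown here, no measured step exchanges acetamido for formyl, so the bearing steps are only indirect. The two steps that leave compound 1, one to chloro and one to acetamido, both moved the number down beyond the scatter, whereas the exchange of chloro for acetamido between compound 2 and compound 3 stayed within it. Three quite different groups at this position thus leave two of three compounds close together, and a fourth group is expected to behave similarly, with no step beyond the scatter. Compound 4 is therefore estimated at 35 uM, within a range of 12 uM to 100 uM. For compound 4 this estimate means an expected step of a 1.1-fold lower number from compound 3 to compound 4 (0.05 log units; within the scatter).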

Compound 4, half-maximal toxic concentration: 0.82 uM
The estimate for compound 4 lay 43-fold (1.63 log units) above the measured number, and the stated range ends above it.
By their numbers in this assay, from the lowest: compound 4; then compounds 2 and 3 (each within the scatter of the next). At a limit, above all of these: compound 1.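

Until now, chloro and acetamido at this aromatic carbon could not be told apart in this assay, which made the position look tolerant of quite different groups, but formyl breaks that picture, with a 48-fold lower number from compound 3 to compound 4 (1.68 log units; beyond the scatter) and a 37-fold lower number from compound 2 to compound 4 (1.57 log units; beyond the scatter). Compound 1, which carries methyl at this position, stands at a limit of the assay and not at a number, so its step can only be read as a bound: an at least 120-fold lower number from compound 1 to compound 4 (2.08 log units; beyond the scatter). The position is therefore far more sensitive to the group it carries than the earlier compounds showed, and nothing measured here accounts for this change.

The compounds shown leave open whether the fall belongs to the formyl group alone or to any carbonyl attached directly to the ring, a question that an acetyl group or a carboxylic acid at this position would address. They also leave open whether a hydroxymethyl group or an amine here would stay near compound 4 or return to the numbers of compound 2 and compound 3.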